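The compounds below may be only part of what the source reports. "The series", "measured", "known", "first", "only" and "open" are said of these compounds alone.

Measured compounds, with their numbers in an assay on isolated protein for inhibition of Neprilysin (Oryctolagus cuniculus); on this read-out higher numbers stand for weaker inhibition and lower numbers for stronger inhibition:
compound 1, `CC[C@H](C)C(S)C(=O)NCC(=O)N1[C@@H](c2ccccc2)CC[C@H]1C(=O)O`, gives 50 nM;
compound 2, `O=C(NCC(=O)N1[C@@H](c2ccccc2)CC[C@H]1C(=O)O)[C@@H](S)Cc1ccc(O)cc1`, gives 3.4 nM;
compound 3, `Nc1ccc(C[C@H](S)C(=O)NCC(=O)N2[C@@H](c3ccccc3)CC[C@H]2C(=O)O)cc1`, gives 1.8 nM.

On these numbers compound 2 stands second highest of the three. Its nearest neighbour is compound 3, reached by a 1.9-fold lower number from compound 2 to compound 3 (0.28 log units; within the scatter); the furthest is compound 1, separated from it by a 15-fold lower number from compound 1 to compound 2 (1.17 log units; beyond the scatter).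

Compound 4, `Cc1ccc([C@H]2CC[C@@H](C(=O)O)N2C(=O)CNC(=O)[C@@H](S)Cc2ccc(O)cc2)cc1`, is compound 2 with methyl in place of hydrogen on an aromatic carbon. The change sits on the shared core, not on the thiol-bearing side chain. The two large steps seen so far, a 15-fold lower number from compound 1 to compound 2 (1.17 log units; beyond the scatter) and a 28-fold lower number from compound 1 to compound 3 (1.44 log units; beyond the scatter), both concern that side chain, and so does the small one, a 1.9-fold lower number from compound 2 to compound 3 (0.28 log units; within the scatter). Within the data shown here, none of the measured steps therefore bears on the change made in compound 4; nothing tells what a methyl on the aromatic ring of the core does. The expected outcome is a 1.2-fold higher number from compound 2 to compound 4 (0.07 log units; within the scatter), in no preferred direction. Compound 4 is expected to give about 4 nM in this assay, within 1.5 nM to 12 nM.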

Compound 4, half-maximal inhibitory concentration: 5.5 nM
Beside the measured number, compound 4's estimate is 1.4-fold (0.14 log units) below it; low and high end bracket the measured number.
By their numbers in this assay, from the lowest: compounds 3, 2 and 4 (each within the scatter of the next, the first and the last beyond it); then compound 1.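

Working from this assay, the step of a 1.6-fold higher number from compound 2 to compound 4 (0.21 log units; within the scatter) is the first read on the shared core rather than the thiol-bearing side chain. It shows that methyl in place of hydrogen on an aromatic carbon, para to a large group, leaves the number of compound 2 within the scatter, so this phenyl to 4-methylphenyl change is tolerated in this assay. No supporting measurement is available to account for this result.

On these data alone, a single small group at one ring position says little about this site as a whole: whether methoxy, an amine or a carboxylic acid in place of the methyl would give a similar number remains open. Also open, as far as these compounds go, is whether the methyl gives the same small step when carried on the side chains of compound 1 or compound 3.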